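The source may hold more compounds than are shown below. What is called first, only, known or untested is meant among the compounds shown, and "the series" means these compounds.

Series of amidine-bearing lactams read in a functional assay on SH-SY5Y cells (Homo sapiens) for cytotoxicity, read by MTT assay, with stated times of 8 h, 30 min and 12 h, tested at 0.05 uM; a lower number here means a weaker effect, a higher number a stronger effect of the compound at the concentration tested. Compound 1 `COc1ccc(CNC(=N)[C@@H]2CCC(=O)N2Cc2ccccc2)cc1` gives 7.1%; compound 2 `N=C(NCc1ccccc1)[C@@H]1CCC(=O)N1Cc1ccccc1[N+](=O)[O-]` gives 10.1%; compound 3 `N=C(NCc1ccc(O)cc1)[C@@H]1CCC(=O)N1Cc1ccccc1[N+](=O)[O-]` gives 20%, the highest of the three numbers, though the gap to compound 2 is within the scatter and only the gap to compound 1 lies beyond it. For the measured compounds named here, the one step recorded, hydroxy in place of hydrogen on an aromatic carbon, reads a number 9.9 percentage points higher from compound 2 to compound 3 (within the scatter), within the scatter.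

Compound 4 `COc1ccc(CNC(=N)[C@@H]2CCC(=O)N2Cc2ccccc2[N+](=O)[O-])cc1` is not yet measured. It differs from compound 3 by methyl in place of hydrogen on an oxygen on an aromatic ring. Going by the values given here, no measured pair shows this change; the nearest bearing is the small movement between compound 2 and compound 3 on the same aromatic ring, and the low value of compound 1, which also carries a methoxy but lacks the nitro group. A step downward or none beyond the scatter in this assay is expected, with compound 4 estimated at 13% within 6% to 22%, meaning an expected step of a number 7 percentage points lower from compound 3 to compound 4 (within the scatter).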

Compound 4, a percentage reported as activity, at one concentration (the size of the read-out at that concentration, not a potency): 18.1%
Compound 4: middle estimate off by 5.1 percentage points, on the low side; measured number inside the range.
By their numbers in this assay, from the lowest: compounds 1, 2, 4 and 3 (each within the scatter of the next, the first and the last beyond it).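

In this assay, methyl in place of hydrogen on the oxygen on the aromatic ring gives a number 1.9 percentage points lower from compound 3 to compound 4 (within the scatter), so the hydroxy and methoxy forms cannot be told apart at this position. Set against plain hydrogen at the same place, the methoxy form gives a number 8 percentage points higher from compound 2 to compound 4 (within the scatter), so this substituent, like hydroxy, is not separated from hydrogen there. For the compounds shown here, the clearer reading comes from elsewhere in the molecule: nitro in place of hydrogen on an aromatic carbon gives a number 11 percentage points higher from compound 1 to compound 4 (beyond the scatter), a modest step and the first single-place change to lie beyond the scatter.

From the compounds shown here alone, whether an amine or a carboxylic acid in place of the methoxy would move the number beyond the scatter remains open. No measured evidence speaks to the reason for these readings.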